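Amide nitrogen substituents on a shared sulfonamide core

The source may hold more compounds than are shown below. What is called first, only, known or untested is meant among the compounds shown, and "the series" means these compounds.

Measured so far:
compound 1, `COc1ccc(-c2csc(C(=O)N(C)C)n2)cc1S(=O)(=O)Nc1cccc(NCCNC(=O)c2cccc(C)c2)c1`, 354 nM
compound 2, `COc1ccc(-c2cccc(C(=O)N(C)CCN(C)C)c2)cc1S(=O)(=O)Nc1cccc(NCCNC(=O)c2cccc(C)c2)c1`, 293 nM

Both compounds were run in a functional assay on CHO-RD-HGA16 cells for agonist activity at Orexin receptor type 2 (Homo sapiens), read by fluorescence and calcium flux, with a stated time of 30 min; a lower number here means that less compound is needed, a higher number that more compound is needed for the effect. Compound 2 has the lower of the two numbers, with compound 1 as its nearest neighbour, but the gap between them lies within the scatter, so no order between the two can be drawn.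

Compound 3, `COc1ccc(-c2cccc(C(=O)N(C)Cc3cccnc3)c2)cc1S(=O)(=O)Nc1cccc(NCCNC(=O)c2cccc(C)c2)c1`, is not yet measured. It differs from compound 2 in one place: pyridin-3-yl in place of (dimethylamino)methyl on a saturated chain carbon bound to an amide-type nitrogen. For the measured compounds named here, no step between two measured compounds isolates this kind of change, so the only guide is that compounds 1 and 2, which differ widely in the group attached to the core, give numbers within the scatter of each other.

For compound 3 the step of a 1.0-fold higher number from compound 2 to compound 3 (0.01 log units; within the scatter) is expected to stay within the scatter, in no clear direction. Compound 3 is therefore estimated at 300 nM, with a range from 100 nM to 900 nM.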

Compound 3, half-maximal effective concentration: 134 nM
Compound 3: the middle estimate sits 2.2-fold (0.35 log units) above what was measured; low and high end bracket the measured number.
By their numbers in this assay, from the lowest: compound 3; then compounds 2 and 1 (each within the scatter of the next).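

For the compounds shown here, exchanging (dimethylamino)methyl for pyridin-3-yl on a saturated chain carbon bound to an amide-type nitrogen gives a 2.2-fold lower number from compound 2 to compound 3 (0.34 log units; beyond the scatter) in this assay and is a modest change, the only one-place step in this set. This position is therefore not indifferent to the group it carries, and for this single pair, a six-membered aromatic ring with one hetero atom is tolerated in place of the open chain without a rise in the number. No measurement available here accounts for the step.

As far as these compounds go, whether the ring nitrogen matters remains open: a plain phenyl group at this place would separate the ring from its nitrogen, and pyridin-2-yl or pyridin-4-yl would show whether the location of that nitrogen counts. A longer chain between the amide nitrogen and the pyridine ring is equally untested in these compounds.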